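Swapping the phenol ring: a step into the unknown

A few compounds are considered here, and "the series" means these few. Any claim that something is new, unique, unknown or untested is made for them only; others in the source may bear on it.

Measured compounds:
compound 1 `O=C(/C(=C\c1ccc(O)c([N+](=O)[O-])c1)SCc1ccc(Cl)cc1)c1ccc(Cl)cc1` with 10000 nM
compound 2 `O=C(/C(=C\c1ccc(O)c([N+](=O)[O-])c1)Sc1ccccc1Br)c1ccc(Cl)cc1` with 25000 nM

In a functional assay on DU-145 cells (Homo sapiens) for inhibition, read by trypan blue exclusion, with a stated time of 96 h (on this read-out lower numbers stand for stronger inhibition of growth and higher numbers for weaker inhibition of growth), compound 1 gives 10000 nM, the lowest of the two numbers shown. Compound 2 sits above it, with a 2.5-fold higher number from compound 1 to compound 2 (0.40 log units; beyond the scatter), a change that sits on the sulfur side of the shared core. Compound 3 `COc1ccc(/C=C(/SCc2ccc(Cl)cc2)C(=O)c2ccc(Cl)cc2)cc1` is not yet measured and differs from compound 1 at the other end of the core: 4-methoxyphenyl in place of 4-hydroxy-3-nitrophenyl on a double-bonded chain carbon bound to a double-bonded chain carbon. Going by the values given here, this change touches a part of the molecule that the single measured step leaves untouched, so that step says nothing direct about what to expect; the only lesson from compound 1 and compound 2 is that one change on the sulfur side moved the number by a modest amount. With no evidence either way on the phenol side, the expectation for this assay is a number near that of compound 1, with the range left wide. Compound 3 is therefore estimated at 15000 nM, between 4000 nM and 60000 nM, which is expected to amount to a 1.5-fold higher number from compound 1 to compound 3 (0.18 log units; within the scatter).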

Compound 3, concentration for 50% growth inhibition: 10000 nM
Compound 3: the middle estimate sits 1.5-fold (0.18 log units) above what was measured; measured number inside the range.
By their numbers in this assay, from the lowest: compounds 1 and 3 (each within the scatter of the next); then compound 2.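

In this assay, the step at this end of the core is no change at the digits printed from compound 1 to compound 3 (within the scatter), so 4-methoxyphenyl and 4-hydroxy-3-nitrophenyl cannot be told apart at this place on a double-bonded chain carbon bound to a double-bonded chain carbon. The nitro group and the hydroxy group both leave here, and the entering group has no hydrogen-bond donor, yet compound 3 stays level with compound 1, which shows that, for this pair, neither group is required for a number of this size. This differs from the one step seen earlier, on the sulfur side of the core, which was a 2.5-fold higher number from compound 1 to compound 2 (0.40 log units; beyond the scatter) and lay beyond the scatter, while no measurement shown here explains why the swap at this end leaves the two numbers level.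

As far as these compounds go, what a ring carrying only the hydroxy group or only the nitro group would give at this place stays open, as does the result of putting an amine or a carboxylic acid on this ring. Also open, from the compounds shown here alone, is whether 4-methoxyphenyl would match 4-hydroxy-3-nitrophenyl just as closely with the 2-bromophenyl on sulfur found in compound 2.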